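This account rests on a few compounds, and the source may have more. Where it says the series, first, only, none or still open, it means among the compounds named here.

Working notes on the series. All compounds share one core and differ only in the amine on a saturated chain carbon bound to an aromatic carbon. Going by the values given here, compound 3 `COc1cc(OC)c(C(=O)/C=C/c2ccccc2Cl)c(O)c1CN1CCCC1` gives 3900 nM in a functional assay on MCF7 cells (Homo sapiens) for antiproliferative activity, with a stated time of 72 h (on this read-out lower numbers stand for stronger inhibition and higher numbers for weaker inhibition), the highest of the three numbers measured so far. Compound 2 `COc1cc(OC)c(C(=O)/C=C/c2ccccc2Cl)c(O)c1CN(C)C` gives 90 nM in this assay, and compound 1 `COc1cc(OC)c(C(=O)/C=C/c2ccccc2Cl)c(O)c1CN(C)CCCN(C)C` gives 3200 nM in this assay. The step of a 43-fold higher number from compound 2 to compound 3 (1.64 log units; beyond the scatter) is large, whereas a 1.2-fold higher number from compound 1 to compound 3 (0.09 log units; within the scatter) lies within the scatter, so compound 3 sits close to compound 1 and far from compound 2.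

The unmeasured compound 4 `COc1cc(OC)c(C(=O)/C=C/c2ccccc2Cl)c(O)c1CN(C)CC(=O)O` differs from compound 3 by (carboxymethyl)(methyl)amino in place of pyrrolidin-1-yl on a saturated chain carbon bound to an aromatic carbon. Among the compounds with values here, the steps that bear on this change are those at the same position: a 43-fold higher number from compound 2 to compound 3 (1.64 log units; beyond the scatter) and a 1.2-fold higher number from compound 1 to compound 3 (0.09 log units; within the scatter). Only the dimethylamino group gave a low number; the two other groups measured here gave numbers within the scatter of each other. Since compound 4 again carries a group other than dimethylamino, no step beyond the scatter is expected in this assay, in either direction, though the uncertainty is wide. Compound 4 is therefore estimated at 4500 nM, between 1000 nM and 20000 nM. This estimate corresponds to an expected step of a 1.2-fold higher number from compound 3 to compound 4 (0.06 log units; within the scatter).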

Compound 4, half-maximal inhibitory concentration: 73200 nM
Estimate against measurement, compound 4: 16-fold (1.21 log units) below; the measured number lies above the stated range.
By their numbers in this assay, from the lowest: compound 2; then compounds 1 and 3 (each within the scatter of the next); then compound 4.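

In this assay the groups other than dimethylamino no longer fall at one level: (carboxymethyl)(methyl)amino gives a 19-fold higher number from compound 3 to compound 4 (1.27 log units; beyond the scatter) and also a 23-fold higher number from compound 1 to compound 4 (1.36 log units; beyond the scatter) on this saturated chain carbon bound to an aromatic carbon. Read as carboxy in place of hydrogen on a saturated chain carbon bound to an amine nitrogen, the change gives an 810-fold higher number from compound 2 to compound 4 (2.91 log units; beyond the scatter) and is the largest step in the series, leaving compound 4 with the highest number of the four. Nothing measured on these compounds accounts for these steps.

Still open, from the compounds shown here alone, is whether an ethyl(methyl)amino group would stay near compound 2 or move towards compound 3. Equally open, going by these compounds, is whether a methyl ester of the carboxylic acid, or a longer chain carrying the acid, would stay near compound 4.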